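The source may hold more compounds than are shown below. What is called first, only, known or untested is meant among the compounds shown, and "the series" means these compounds.

Compound 1 `O=C1c2ccccc2N(Cc2ccccc2Cl)S(=O)(=O)N1Cc1ccccc1Cl` is one of two compounds tested in a functional assay on HEL cells (Homo sapiens) for inhibition; on this read-out higher numbers stand for lower toxicity in this test and lower numbers for higher toxicity in this test. In this assay compound 1 gives > 200000 nM, which is a limit of the assay and not a number. Compound 2 `O=C1c2ccccc2N(Cc2ccccc2)S(=O)(=O)N1COCc1ccccc1` is the other. In this assay compound 2 gives > 98000 nM, likewise a limit. Compound 1 thus stands at the limit of > 200000 nM in this assay, at which 1 of the 2 values shown sits. Compound 2 stands at the limit of > 98000 nM in this assay, at which 1 of the 2 values shown sits. Both values shown are limits, so the two compounds cannot be put in order against each other. Compound 3 `O=C1c2ccccc2N(Cc2ccccc2Cl)S(=O)(=O)N1Cc1ccccc1` has not yet been measured. It differs from compound 1 by hydrogen in place of chloro on an aromatic carbon, so that one 2-chlorobenzyl group becomes benzyl. No measured step of this kind is shown. The expected step from compound 1 to compound 3 in this assay is a number no higher from compound 1 to compound 3 (the limit leaves the size open), none beyond the scatter. Compound 3 is estimated at 200000 nM, with a range from 50000 nM to 500000 nM, and is expected most likely to be reported again as a limit.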

Compound 3, half-maximal cytotoxic concentration: 88000 nM
Beside the measured number, compound 3's estimate is 2.3-fold (0.36 log units) above it; low and high end bracket the measured number.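

For the compounds shown here, with compound 3, this assay yields the first reading that is a number and not a limit, and with it the first step that can be read. Replacing chloro with hydrogen on an aromatic carbon, ortho to a large group, gives an at least 2.2-fold lower number from compound 1 to compound 3 (0.35 log units; beyond the scatter), so this position is not indifferent to the change: the lower number stands for higher toxicity in this test. Compound 1 stands at a limit and not a number, so the true size of the step stays open: the limit of > 200000 nM in this assay, at which 1 of the 3 values shown sits.

The compounds shown leave open whether the chloro on the remaining 2-chlorobenzyl group matters in the same way. They also leave open how a fluoro or a methoxy group would read at the position tested here.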